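A few compounds are considered here, and "the series" means these few. Any claim that something is new, unique, unknown or untested is made for them only; others in the source may bear on it.

For the measured compounds named here, in an ADME assay on L6 cells (Rattus norvegicus) for cytotoxicity, read by fluorescence and resazurin assay, with a stated time of 72 h (on this read-out lower numbers stand for higher toxicity in this test and higher numbers for lower toxicity in this test), two compounds have numbers so far. Compound 1 (`CC(C)c1ccc(-c2c[nH]cc2C(c2ccc(Cl)cc2Cl)n2ccnc2)cc1`) gives 12700 nM and compound 2 (`Clc1ccc(-c2cc(C(c3ccc(Cl)cc3)n3ccnc3)c[nH]2)cc1`) gives 6650 nM, and these two values lie within the usual scatter of each other. Compound 3 (`Cn1cc(C(c2ccc(Cl)cc2)n2ccnc2)cc1-c1ccc(Cl)cc1`) has yet to be measured. It departs from compound 2 in one place: methyl in place of hydrogen on an aromatic nitrogen. Going by the values given here, no measured pair shows what this change does in this assay. Compound 1 is substituted differently around the shared core, yet its 12700 nM lies within the scatter of compound 2 at 6650 nM, so only a small difference is expected here. The expected size of a 1.2-fold higher number from compound 2 to compound 3 (0.08 log units; within the scatter) is nothing beyond the scatter. Compound 3 is estimated at 8000 nM, with an expected range of 3000 nM to 22000 nM.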

Compound 3, half-maximal cytotoxic concentration: 12100 nM
The estimate for compound 3 lay 1.5-fold (0.18 log units) below the measured number; the range from low to high includes it.
By their numbers in this assay, from the lowest: compounds 2, 3 and 1 (each within the scatter of the next).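

In this assay, for the compounds shown here, the pair of compounds that isolates this change gives a 1.8-fold higher number from compound 2 to compound 3 (0.26 log units; within the scatter) and so provides the first direct reading at this position: methyl in place of hydrogen on an aromatic nitrogen, next to the ring atom that bears a 4-chlorophenyl group, leaves the number within the usual scatter. This reading rests on a single pair. The step in that pair does not go beyond the scatter in this test. Nothing available explains the size of this step.

From the compounds shown here alone, whether a larger group on this nitrogen, such as an ethyl group, a longer chain or a chain ending in an amine, would also stay within the scatter remains open. Also open, going by these compounds, is whether the same methyl change would give a similar step on the differently substituted core of compound 1.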